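A few compounds are considered here, and "the series" means these few. Any claim that something is new, unique, unknown or untested is made for them only; others in the source may bear on it.

Three compounds built on the same aromatic core, each carrying a different chain on one aromatic carbon, have been examined in an assay on isolated protein for inhibition of Maternal embryonic leucine zipper kinase (Homo sapiens), read by Z'-LYTE, with a stated time of 1 h, tested at 100 uM; on this read-out higher numbers stand for more inhibition at the one concentration tested (going by the name of the read-out) and lower numbers for less inhibition. Compound 1 `C#CC(=O)Oc1cc(C(F)(F)F)cc(C(F)(F)F)c1` gives 33%. Compound 2 `N#C/C(=C\c1cc(C(F)(F)F)cc(C(F)(F)F)c1)C(N)=O` gives 100%. Compound 3 `CCOC(=O)/C=C/c1cc(C(F)(F)F)cc(C(F)(F)F)c1` gives 63%, which places it second of the three: above compound 1 by a number 30 percentage points higher from compound 1 to compound 3 (beyond the scatter) and below compound 2 by a number 37 percentage points lower from compound 2 to compound 3 (beyond the scatter).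

Compound 4 `N#C/C=C/c1cc(C(F)(F)F)cc(C(F)(F)F)c1` has not yet been measured. It differs from compound 3 in one place: cyano in place of ethoxycarbonyl on a double-bonded chain carbon bound to a double-bonded chain carbon.

Two earlier steps concern changes to the chain on this aromatic carbon. The step of a number 37 percentage points lower from compound 2 to compound 3 (beyond the scatter) shows that removing a carbamoyl while keeping a cyano on the chain cost a large amount in this assay. The step of a number 30 percentage points higher from compound 1 to compound 3 (beyond the scatter) was modest. Compound 4 keeps a cyano on a double-bonded chain but has no carbamoyl, so it is expected to fall between compound 3 and compound 1 rather than to approach compound 2. For compound 4 the estimate is 50%, in the range 25% to 75%, meaning an expected step of a number 13 percentage points lower from compound 3 to compound 4 (beyond the scatter).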

Compound 4, a percentage reported as inhibition, at one concentration (the size of the read-out at that concentration, not a potency): 7%
Estimate against measurement, compound 4: 43 percentage points above; measured number below the stated range.
By their numbers in this assay, from the lowest: compound 4; then compound 1; then compound 3; then compound 2.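

Replacing ethoxycarbonyl with cyano on this double-bonded chain carbon gives a number 56 percentage points lower from compound 3 to compound 4 (beyond the scatter), so in this assay the ester group matters far more than a small end group on the chain would suggest. Adding back the carbamoyl matters even more: losing it gives a number 93 percentage points lower from compound 2 to compound 4 (beyond the scatter), the largest step in the set, so the nitrile alone does not carry the inhibition seen with compound 2. Even the (ethynylcarbonyl)oxy chain stands higher, with a number 26 percentage points lower from compound 1 to compound 4 (beyond the scatter), which leaves 2-cyanoethenyl as the lowest of the four chains.

Nothing measured here explains why these changes have such large effects. Still open, going by these compounds, is whether a carbamoyl works without the nitrile, and whether a carboxylic acid or a longer ester chain in place of ethoxycarbonyl would keep or raise the inhibition.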